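Furan-3-yl at the aryl position of the shared core

The source may report more compounds than this note shows. Statements on the series, on what has been measured and on what is new or still open speak of the compounds shown alone.

Within the data shown here, in an assay on NIH3T3 cells for inhibition of Sonic hedgehog protein (Mus musculus), read by a luciferase reporter, with a stated time of 48 h (on this read-out higher numbers stand for weaker inhibition and lower numbers for stronger inhibition), compound 2 `Cc1cnc(Nc2ccc(C(=O)Nc3c(C)cccc3C)cc2)nc1-c1ccc(F)cc1` gives 2.2 nM, the only number among the two values shown. Compound 1 `Cc1cnc(Nc2ccc(C(=O)Nc3c(C)cccc3C)cc2)nc1-c1ccccc1OC(F)(F)F` gives > 500 nM in this assay, which is a limit, not a number (the limit of > 500 nM in this assay, at which 1 of the 2 values shown sits). Among the measured compounds shown here, the one measured step, an at least 220-fold lower number from compound 1 to compound 2 (2.35 log units; beyond the scatter), shows that this position sets the outcome. Compound 3 `Cc1cnc(Nc2ccc(C(=O)Nc3c(C)cccc3C)cc2)nc1-c1ccoc1` differs from compound 2 by furan-3-yl in place of 4-fluorophenyl on an aromatic carbon. With a single step to draw on, an expected change of a 4.5-fold higher number from compound 2 to compound 3 (0.66 log units; beyond the scatter) is estimated, toward weaker inhibition but not as far as the limit. Compound 3 is expected at 10 nM, with a range from 2 nM to 120 nM.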

Compound 3, half-maximal inhibitory concentration: 15.7 nM
Compound 3: the middle estimate sits 1.6-fold (0.20 log units) below what was measured; the measured number falls inside the stated range.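

In this assay, this position proves not to be tied to 4-fluorophenyl: the five-membered aromatic ring of furan-3-yl gives a 7.1-fold higher number from compound 2 to compound 3 (0.85 log units; beyond the scatter), a modest step, while the change from 2-(trifluoromethoxy)phenyl gives an at least 31-fold lower number from compound 1 to compound 3 (1.50 log units; beyond the scatter), a large one. The loss from 4-fluorophenyl to furan-3-yl is thus much smaller than the gap to compound 1. Compound 1 stays a limit, not a number: the limit of > 500 nM in this assay, at which 1 of the 3 values shown sits.

The compounds shown leave open how a plain phenyl, an amine or a carboxylic acid would fare at this position.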